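This account rests on a few compounds, and the source may have more. Where it says the series, first, only, none or still open, it means among the compounds named here.

Measured in a functional assay on cells (Platelet, Homo sapiens) for inhibition; a higher number here means a weaker inhibitor, a lower number a stronger inhibitor:
Compound 1 `COC(=O)c1ccc(-c2nn(Cc3ccccc3)c3ccccc23)cc1`: > 10000 nM
Compound 2 `CCCOC(=O)c1ccc(-c2nn(Cc3ccccc3)c3ccccc23)cc1`: > 10000 nM
Compound 3 `CCCNC(=O)c1ccc(-c2nn(Cc3ccccc3)c3ccccc23)cc1`: > 10000 nM

Compound 3 has no exact number, only the limit > 10000 nM. Its two relatives are in the same position, as the whole set shows: the limit of > 10000 nM in this assay, at which 3 of the 3 values shown sit.

Compound 4 `OCc1ccc(-c2nn(Cc3ccccc3)c3ccccc23)cc1` carries hydroxymethyl in place of propylcarbamoyl on an aromatic carbon, para to a large group (hydroxymethyl in place of propylcarbamoyl on an aromatic carbon).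

The measured steps that bear on this change all alter the same group: a step that the two limits leave unreadable from compound 1 to compound 2, a step that the two limits leave unreadable from compound 1 to compound 3 and a step that the two limits leave unreadable from compound 2 to compound 3. None of them has a readable size, so they offer no firm guide to size or direction. The expected step, a step that the limit leaves unreadable from compound 3 to compound 4, is therefore only a cautious estimate. For compound 4 the estimated value is 12000 nM, with an expected range from 3000 nM to 40000 nM.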

Compound 4, half-maximal inhibitory concentration: > 10000 nM
Compound 4: no number, only a limit (the forecaster's own chance of this, stated with the estimate: 55%); the middle value lies beyond the limit too.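

Among these compounds, compound 4 gives only a limit, > 10000 nM, so no step between compound 4 and compound 1, compound 2 or compound 3 can be read. The compounds shown leave open whether any group in this place gives an exact value.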